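A few compounds are considered here, and "the series" means these few. Any claim that something is new, unique, unknown or untested is made for them only; others in the source may bear on it.

Among the measured compounds shown here, compound 2 `COC(=O)[C@@]1(C)CCC=C2[C@@H]1CC[C@@H](C)[C@]2(C)Cc1c(C)[nH]c2ccccc12` is the weaker of the two compounds measured so far. In a functional assay on HeLa cells (Homo sapiens) for inhibition, read by sulforhodamine B assay, with a stated time of 48 h (a lower number here means a stronger inhibitor of growth, a higher number a weaker inhibitor of growth), compound 2 gives 11000 nM, the higher of the two numbers. For the measured compounds named here, the only comparison on hand is compound 1 `COC(=O)[C@@]1(C)CCC=C2[C@@H]1CC[C@@H](C)[C@]2(C)Cc1c[nH]c2ccccc12`, which differs from compound 2 by a hydrogen in place of that methyl on an aromatic carbon; in this assay compound 1 gives 3600 nM. That single step, a 3.1-fold higher number from compound 1 to compound 2 (0.49 log units; beyond the scatter), is the whole record.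

Compound 3 `COC(=O)[C@@]1(C)CCC=C2[C@@H]1CC[C@@H](C)[C@]2(C)Cc1c(C=O)[nH]c2ccccc12` changes the same place again: formyl in place of methyl on an aromatic carbon. Going by the values given here, no measured step exchanges a methyl for a formyl, so the hydrogen-to-methyl step is only an indirect guide, showing that change at this spot cost a modest amount rather than a large one. The expectation for compound 3 is therefore a number near that of compound 2, with a wide range either way, a 1.2-fold lower number from compound 2 to compound 3 (0.09 log units; within the scatter). The estimate for compound 3 in this assay is 9000 nM, expected to fall between 2500 nM and 30000 nM.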

Compound 3, concentration for 50% growth inhibition: 4400 nM
Beside the measured number, compound 3's estimate is 2.0-fold (0.31 log units) above it, within the range that was stated.
By their numbers in this assay, from the lowest: compounds 1 and 3 (each within the scatter of the next); then compound 2.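

In this assay, the formyl in place of methyl gives a 2.5-fold lower number from compound 2 to compound 3 (0.40 log units; beyond the scatter) and so shows that the cost seen with the methyl does not apply to every group placed at this spot. Formyl in place of hydrogen gives a 1.2-fold higher number from compound 1 to compound 3 (0.09 log units; within the scatter) and so shows that this position, on the five-membered aromatic ring next to the ring nitrogen, can carry a formyl with no change beyond the scatter. Nothing on hand explains why methyl and formyl differ here.

With only hydrogen, methyl and formyl to compare, no trend across groups at this position can be drawn. Going by these compounds, whether a carboxylic acid, an amine or a longer chain would match the formyl, match the methyl or do something else remains open.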